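A few compounds are considered here, and "the series" means these few. Any claim that something is new, unique, unknown or untested is made for them only; others in the source may bear on it.

Compound 1 `CCc1cccc2c(OC)c(-c3occ(C)c3C(=S)OC)ccc12`, compound 2 `CCc1cccc2c(OC)c(-c3occ(C)c3C(=O)On3nnc4ccccc43)ccc12` and compound 3 `CCc1cccc2c(OC)c(-c3occ(C)c3COC)ccc12` share one core and differ only in the side chain carried on its aromatic carbon. In a functional assay on ZR-75-1 cells (Homo sapiens) for cytotoxicity, read by MTT assay, with a stated time of 72 h (on this read-out higher numbers stand for an effect only at larger amounts of compound and lower numbers for an effect already at smaller amounts), compound 1 gives 5.8 ug/mL. Compound 3 gives 9.7 ug/mL in this assay, the higher of the two numbers recorded, though the step of a 1.7-fold higher number from compound 1 to compound 3 (0.22 log units; within the scatter) is within the scatter, so the two compounds cannot be told apart. For compound 2 the assay reports only a limit, > 10 ug/mL, and no number; this is the limit of > 10 ug/mL in this assay, at which 1 of the 3 values shown sits.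

Compound 4 `CCc1cccc2c(OC)c(-c3occ(C)c3COC(=O)CCN(CC)CC)ccc12` differs from compound 3 by (2-(diethylamino)ethyl)carbonyl in place of methyl on an oxygen on a saturated carbon. Among the compounds with values here, the one measured step that touched this side chain, a 1.7-fold higher number from compound 1 to compound 3 (0.22 log units; within the scatter), was small, while the only compound whose side chain grew to a comparable size, compound 2, returned a limit rather than a number. Thus the data offer no measured step that predicts the effect of the new ester, and a shift either way remains possible. Compound 4 is therefore expected to land near compound 3, at an estimated 9 ug/mL, with a range from 3.5 ug/mL to 20 ug/mL, a step of a 1.1-fold lower number from compound 3 to compound 4 (0.03 log units; within the scatter) that is expected to stay within the scatter.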

Compound 4, concentration for half-maximal effect: 1.7 ug/mL
Compound 4: middle estimate off by 5.3-fold (0.72 log units), on the high side; the measured number lies below the stated range.
By their numbers in this assay, from the lowest: compound 4; then compounds 1 and 3 (each within the scatter of the next). At a limit, above all of these: compound 2.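

Within the data shown here, the step of a 5.7-fold lower number from compound 3 to compound 4 (0.76 log units; beyond the scatter) in this assay is the first change at this side chain that lies beyond the scatter, whereas a 1.7-fold higher number from compound 1 to compound 3 (0.22 log units; within the scatter) could not be told from repeat measurement. It shows that the number responds to what is carried on the oxygen on the saturated carbon, and that putting (2-(diethylamino)ethyl)carbonyl in place of methyl, a much larger group, goes with a lower number here and not with a loss of effect. Nothing in the data shown gives a cause for this step.

On these data alone, the change brings in a carbonyl and a diethylamino end together, so it remains open which of them goes with the lower number, and an acetyl group, which has the carbonyl without the amine, or a longer chain leading to the same amine would separate the two. Compound 2 also stays unplaced against this result, since it offers a limit and not a number: the limit of > 10 ug/mL in this assay, at which 1 of the 4 values shown sits.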